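Adding a fluorine to a cinnamamide series: expected effect

This account rests on a few compounds, and the source may have more. Where it says the series, first, only, none or still open, it means among the compounds named here.

Compound 1 `O=C(/C=C/c1ccccc1)Nc1nnc(-c2ccccc2)s1` is the starting point. In a functional assay on MCF7 cells (Homo sapiens) for antiproliferative activity, read by MTT assay, with a stated time of 48 h (a higher number here means a weaker inhibitor, a lower number a stronger inhibitor), compound 1 gives 1.47 ug/mL. Compound 2 `O=C(/C=C/c1ccc(F)cc1)Nc1nnc(-c2ccccc2)s1` differs from it by fluoro in place of hydrogen on an aromatic carbon, and compound 2 gives 1.45 ug/mL; the step of a 1.0-fold lower number from compound 1 to compound 2 (0.01 log units; within the scatter). Compound 3 `Cc1ccc(-c2nnc(NC(=O)/C=C/c3ccccc3)s2)cc1` carries a different core, and the difference between the two cores is methyl in place of hydrogen on an aromatic carbon; compound 3 gives 1.19 ug/mL, a step of a 1.2-fold lower number from compound 1 to compound 3 (0.09 log units; within the scatter).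

Compound 4 `Cc1ccc(-c2nnc(NC(=O)/C=C/c3ccc(F)cc3)s2)cc1` has not been measured. It differs from compound 3 by fluoro in place of hydrogen on an aromatic carbon, the same change that turns compound 1 into compound 2, made here on the core of compound 3, and the place described for both is identical. Since that change left the number essentially unmoved (a 1.0-fold lower number from compound 1 to compound 2 (0.01 log units; within the scatter)), the expectation for compound 4 is a comparably small step from compound 3, estimated as a 1.0-fold lower number from compound 3 to compound 4 (0.00 log units; within the scatter). This rests on a single prior example and on two cores that are close, so the uncertainty is that of ordinary repeat scatter rather than of a real trend. The estimated value for compound 4 in this assay is 1.18 ug/mL, expected to fall between 0.7 ug/mL and 2 ug/mL.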

Compound 4, half-maximal inhibitory concentration: 1.27 ug/mL
For compound 4 the middle estimate is 1.1-fold (0.03 log units) below the measured one; measured number inside the range.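

In this assay, fluoro in place of hydrogen on the core of compound 3 gives a 1.1-fold higher number from compound 3 to compound 4 (0.03 log units; within the scatter), and this agrees with the same change on the core of compound 1: the same change on two cores in this assay, a 1.0-fold lower number (0.01 log units; within the scatter) from compound 1 to compound 2 and a 1.1-fold higher number (0.03 log units; within the scatter) from compound 3 to compound 4, 1.1-fold (0.03 log units) apart, within the scatter of two such steps. The methyl change, read on the fluorinated pair, gives a 1.1-fold lower number from compound 2 to compound 4 (0.06 log units; within the scatter), and it agrees with its earlier counterpart too: the same change on two cores in this assay, a 1.2-fold lower number (0.09 log units; within the scatter) from compound 1 to compound 3 and a 1.1-fold lower number (0.06 log units; within the scatter) from compound 2 to compound 4, 1.1-fold (0.03 log units) apart, within the scatter of two such steps. So across these four compounds each change leaves the number about where it was on both cores, but all of these steps lie within the scatter, which means the agreement shows only that neither change has a measurable effect here, not that a change with a real effect would carry from one core to the other.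

As far as these compounds go, it remains open whether a group such as an amine, a carboxylic acid or a longer chain, set in the same place, would move the number at all. If one did, it would still have to be seen whether that step stays the same size on both cores.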